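Removing One Carboxymethyl Group from a Doubly Substituted Flavonoid

The source may hold more compounds than are shown below. What is called first, only, known or untested is meant among the compounds shown, and "the series" means these compounds.

Compound 1 `COc1ccc(-c2oc3c(CC=C(C)C)c(OCC(=O)O)cc(O)c3c(=O)c2OCC(=O)O)cc1` carries two carboxymethyl groups on its shared core. In a functional assay on A549 cells (Homo sapiens) for cytotoxicity, read by MTT assay (on this read-out higher numbers stand for weaker inhibition and lower numbers for stronger inhibition), compound 1 reaches only the limit of the measurement, > 100000 nM, so no number is known for it. Two neighbours in the same series give numbers: compound 2 `COc1ccc(-c2oc3c(CC=C(C)C)c(OCCOC(=O)CCCC(=O)O)cc(O)c3c(=O)c2OCCOC(=O)CCCC(=O)O)cc1` shows 6100 nM in this assay, and compound 3 `CCOC(=O)C(C)Oc1c(-c2ccc(OC)cc2)oc2c(CC=C(C)C)c(O)cc(O)c2c1=O` shows 4600 nM. Compound 1 therefore stands apart from both, sitting at the limit of > 100000 nM in this assay, at which 1 of the 3 values shown sits.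

Compound 4 `COc1ccc(-c2oc3c(CC=C(C)C)c(OCC(=O)O)cc(O)c3c(=O)c2O)cc1` is the next compound to be tested. It differs from compound 1 in a single place: hydrogen in place of carboxymethyl on an oxygen on an aromatic ring. The second carboxymethyl group, the one on the other oxygen, remains in place.

Within the data shown here, no pair of measured compounds differs in just this way, so the size of the step cannot be read off directly. Compounds 2 and 3, which carry fewer free carboxymethyl groups than compound 1, both give measurable numbers, which suggests that the change toward compound 4 may move the value inward from the limit. The step from compound 1 to compound 4 is expected to be an at least 2.0-fold lower number from compound 1 to compound 4 (0.30 log units; that floor lies within the scatter). For compound 4 the estimated value in this assay is 50000 nM, with a plausible range from 10000 nM to 200000 nM, and a real chance that only a limit is reported again.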

Compound 4, half-maximal inhibitory concentration: 16700 nM
Compound 4: middle estimate off by 3.0-fold (0.48 log units), on the high side; the measured number falls inside the stated range.
By their numbers in this assay, from the lowest: compounds 3 and 2 (each within the scatter of the next); then compound 4. At a limit, above all of these: compound 1.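

Swapping one carboxymethyl group for hydrogen on an oxygen on an aromatic ring gives an at least 5.9-fold lower number from compound 1 to compound 4 (0.77 log units; beyond the scatter) in this assay, the first step in this series that can be read at all. This shows that the change at this single oxygen is enough to bring the value inside the measurable range, even though compound 4 still carries its other carboxymethyl group and gives 16700 nM. The step is only a floor, and its true size stays unknown, because its starting point, compound 1, is a limit and not a number: the limit of > 100000 nM in this assay, at which 1 of the 4 values shown sits.

The compounds shown leave open whether the same swap on the other oxygen would give a step of similar size, and what a compound with hydroxy in place of both carboxymethyl groups would give. They also leave open whether hydrogen is the best replacement at this oxygen, or whether a short chain ending in an amine, or a longer chain ending in a carboxylic acid with the other oxygen left unchanged, would move the number further.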